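The source may report more compounds than this note shows. Statements on the series, on what has been measured and on what is new or still open speak of the compounds shown alone.

Measured compounds in this set:
compound 1, `Nc1cc(N)c2nc(-c3ccccc3)c(Oc3ccc(Cl)c(Cl)c3)nc2c1`, 69200 nM;
compound 2, `Nc1cc(N)c2nc(-c3ccccc3)c(NCc3ccc(Cl)c(Cl)c3)nc2c1`, 89100 nM;
compound 3, `CCOC(=O)[C@H](CCC(=O)O)NC(=O)c1ccc(Sc2nc3cc(N)cc(N)c3nc2-c2ccccc2)cc1`, a limit.

In a functional assay on SF-295 cells (Homo sapiens) for inhibition, read by sulforhodamine B assay, with a stated time of 48 h (on this read-out lower numbers stand for higher toxicity in this test and higher numbers for lower toxicity in this test), compound 1 gives 69200 nM, the smaller of the two numbers shown, though the gap to compound 2 lies within the scatter. Compound 2 gives 89100 nM in this assay. For compound 3 the result in this assay is < 100000 nM, which is a limit of the assay and not a number; it is the limit of < 100000 nM in this assay, at which 1 of the 3 values shown sits.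

Compound 4, `Nc1cc(N)c2nc(-c3ccccc3)c(Sc3ccc(F)cc3)nc2c1`, has not yet been measured in this assay. It differs from compound 1 in one place: (4-fluorophenyl)sulfanyl in place of 3,4-dichlorophenoxy on an aromatic carbon. Within the data shown here, no measured pair in this set differs in a single place, so no measured step gives a size for such a change. The two numbers shown sit within the scatter of each other, and the shared core carries both through this range.

Compound 4 is therefore expected to stay in that range, with a step from compound 1 of a 1.1-fold lower number from compound 1 to compound 4 (0.03 log units; within the scatter) that is not expected to reach beyond the scatter. The estimate for compound 4 in this assay is 65000 nM, within 25000 nM to 110000 nM.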

Compound 4, concentration lethal to 50% of the cells: 64600 nM
Compound 4: the middle estimate sits 1.0-fold (0.00 log units) above what was measured; the measured number falls inside the stated range.
By their numbers in this assay, from the lowest: compounds 4, 1 and 2 (each within the scatter of the next).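

In this assay, among these compounds, replacing 3,4-dichlorophenoxy with (4-fluorophenyl)sulfanyl on the aromatic carbon next to the ring nitrogen gives a 1.1-fold lower number from compound 1 to compound 4 (0.03 log units; within the scatter), the only step in this set that can be read between compounds differing in one place. It shows that this position accepts a different aryl-bearing group, with another linking atom and another halogen pattern on the six-membered aromatic ring, without a shift beyond the scatter. Nothing in the data bears on why the result stays within the scatter.

The linking atom and the halogens changed together in this single step, so the compounds shown do not separate the contribution of the sulfur from that of the fluorine, and a matched pair that alters only one of them would be needed to do so. On these data alone, it also remains open whether the read-out in this assay would stay in this range with a group lacking the aromatic ring at this position, such as a piperazine or a plain alkyl chain on that carbon.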